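The source may report more compounds than this note shows. Statements on the series, on what has been measured and on what is new or still open speak of the compounds shown alone.

Among the compounds with values here, compound 1 `CN(C)c1cc2[nH]c(C3CCCCC3)nc2cc1NC(=O)c1ccc(Br)cc1` is the one member of this small set with a result in hand. In an ADME assay on Vero cells (Chlorocebus sabaeus) for cytotoxicity, read by resazurin assay, with a stated time of 3 days (on this read-out higher numbers stand for weaker inhibition and lower numbers for stronger inhibition), compound 1 gives > 100 ug/mL, which is a limit of the assay rather than a number. the limit of > 100 ug/mL in this assay, at which 1 of the 2 values shown sits, is where compound 1 stands, so all that is known is that no inhibition was reached up to that point. A second member, compound 2 `CCN(CC)c1cc2[nH]c(C3CCCCC3)nc2cc1NC(=O)c1ccc(N(C)C)cc1`, has in this assay only "not determined" (no result reported), and so contributes no number at all. Compound 3 `CCOCCOC(=O)Nc1cc2nc(C3CCCCC3)[nH]c2cc1N(C)C` has not been measured. It differs from compound 1 by 2-ethoxyethoxy in place of 4-bromophenyl on a carbonyl carbon. Within the data shown here, with no measured step between any two compounds to lean on, the expected step of a number no higher from compound 1 to compound 3 (the limit leaves the size open) is estimated to be none beyond the scatter. Compound 3 is accordingly estimated at 100 ug/mL, with a range from 40 ug/mL to 250 ug/mL, and most likely again reported only as a limit.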

Compound 3, half-maximal inhibitory concentration: > 100 ug/mL
Compound 3: a limit, no number (the forecaster's own chance of this, stated with the estimate: 70%); the middle value sits exactly at the limit.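

Within the data shown here, compound 1 and compound 3 both give only a limit of the assay in this assay, so no step between them can be read: the limit of > 100 ug/mL in this assay, at which 2 of the 3 values shown sit. The compounds shown leave open whether 2-ethoxyethoxy in place of 4-bromophenyl on a carbonyl carbon makes any difference to cytotoxicity.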